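A few compounds are considered here, and "the series" means these few. Any claim that something is new, unique, unknown or untested is made for them only; others in the source may bear on it.

Measured so far:
compound 1, `CC[C@H](C)[C@H](N)CN(C(=O)[C@@H]1C[C@H]1c1cccc(C)c1)c1ccc(-c2ccccc2)cc1`, in a functional assay for agonist activity at G protein-coupled receptor 88 (Homo sapiens), read by HTRF and cAMP accumulation (a higher number here means that more compound is needed for the effect, a lower number that less compound is needed), gives 1200 nM;
compound 2, `CC[C@H](C)[C@H](N)CN(C(=O)[C@@H]1C[C@H]1c1nc(C)cs1)c1ccc(-c2ccccc2)cc1`, in this assay gives 730 nM.

Within the data shown here, compound 2 stands beside compound 1 as one of only two measured compounds, and the single step that joins them, a 1.6-fold lower number from compound 1 to compound 2 (0.22 log units; within the scatter), lies within the scatter, so the two numbers cannot be told apart.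

Compound 3, `CC[C@H](C)[C@H](N)CN(C(=O)[C@@H]1C[C@H]1c1csc(C)n1)c1ccc(-c2ccccc2)cc1`, has not yet been measured. It differs from compound 2 in one place: 2-methyl-1,3-thiazol-4-yl in place of 4-methyl-1,3-thiazol-2-yl on a saturated ring carbon. Among the measured compounds shown here, the only measured step that touches this saturated ring carbon is a 1.6-fold lower number from compound 1 to compound 2 (0.22 log units; within the scatter), in which a whole aromatic ring was exchanged for another without a change beyond the scatter. For the measured compounds named here, the present change is smaller in kind, a rearrangement of the same atoms within the thiazole rather than a new ring, and nothing among the measured compounds speaks for a shift in either direction. The step from compound 2 to compound 3 in this assay is therefore expected to stay within the scatter, a 1.2-fold higher number from compound 2 to compound 3 (0.09 log units; within the scatter). For compound 3 the estimate in this assay is 900 nM, with a range from 350 nM to 2300 nM.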

Compound 3, half-maximal effective concentration: 1500 nM
The estimate for compound 3 lay 1.7-fold (0.22 log units) below the measured number, within the range that was stated.
By their numbers in this assay, from the lowest: compounds 2, 1 and 3 (each within the scatter of the next, the first and the last beyond it).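

In this assay the position on the saturated ring carbon of the cyclopropyl proves able to tell two isomeric thiazoles apart: the atoms and the counts stay the same, yet the exchange of 4-methyl-1,3-thiazol-2-yl for 2-methyl-1,3-thiazol-4-yl gives a 2.1-fold higher number from compound 2 to compound 3 (0.31 log units; beyond the scatter) as a modest step, the first one here that clears the scatter. The 3-methylphenyl group, by contrast, remains indistinguishable from this thiazole as well, with a 1.3-fold higher number from compound 1 to compound 3 (0.10 log units; within the scatter) and no separation from either heterocycle, so the only difference that can be read lies between the two thiazoles and not between the phenyl and thiazole rings. Nothing at hand offers an explanation for the step between the two thiazoles.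

That step moves the ring's point of attachment and the methyl group together, and these three compounds cannot show which of the two carries it. As far as these compounds go, how an unsubstituted 1,3-thiazol-4-yl, an ethyl group in place of the methyl, an amine on the thiazole or an oxazole ring would fare at this position remains open.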